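Moving a Methyl Around the Aniline Ring

The source may report more compounds than this note shows. Statements on the series, on what has been measured and on what is new or still open speak of the compounds shown alone.

Values in a functional assay on BGC-823 cells (Homo sapiens) for cytotoxicity, read by MTT assay; on this read-out higher numbers stand for weaker inhibition and lower numbers for stronger inhibition:
Compound 1 `Cc1cccc(Nc2nc(C)c(C(=O)/C=C/c3ccccc3Cl)s2)c1`: 24200 nM
Compound 2 `COc1cc(/C=C/C(=O)c2sc(Nc3ccccc3C)nc2C)cc(OC)c1OC`: 5400 nM
Compound 3 `Cc1ccccc1Nc1nc(C)c(C(=O)/C=C/c2ccccc2Cl)s1`: > 25000 nM, a limit of this assay rather than a number.

Compound 2 has the lowest of the two numbers; compound 1 gives a higher number, and that gap lies beyond the scatter. The cores of compound 2 and compound 3 differ in more than one place, and the difference is not broken down here.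

One change is seen between measured compounds: 3-methylphenyl in place of 2-methylphenyl on a nitrogen on an aromatic ring. Its step is an at least 1.0-fold lower number from compound 3 to compound 1 (0.01 log units; that floor lies within the scatter). Its size is uncertain because compound 3 sits at the limit of > 25000 nM in this assay, at which 1 of the 3 values shown sits.

Compound 4 `COc1cc(/C=C/C(=O)c2sc(Nc3cccc(C)c3)nc2C)cc(OC)c1OC` is not yet measured. It differs from compound 2 by the same change: 3-methylphenyl in place of 2-methylphenyl on a nitrogen on an aromatic ring. Since the measured step of an at least 1.0-fold lower number from compound 3 to compound 1 (0.01 log units; that floor lies within the scatter) is flat within the scatter, the step from compound 2 to compound 4 in this assay is expected to be about a 1.1-fold lower number from compound 2 to compound 4 (0.03 log units; within the scatter). Compound 4 is therefore estimated at 5000 nM, between 2000 nM and 15000 nM.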

Compound 4, half-maximal inhibitory concentration: 17200 nM
Beside the measured number, compound 4's estimate is 3.4-fold (0.54 log units) below it; measured number above the stated range.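

Putting 3-methylphenyl in place of 2-methylphenyl on the nitrogen gives, in this assay, a 3.2-fold higher number from compound 2 to compound 4 (0.50 log units; beyond the scatter), so on this core the change goes with weaker inhibition. The change therefore does not carry over from one core to the other as a single fixed step, and a result on one core is a poor guide to the other: the same change on two cores in this assay, an at least 1.0-fold lower number (0.01 log units; that floor lies within the scatter) from compound 3 to compound 1 and a 3.2-fold higher number (0.50 log units; beyond the scatter) from compound 2 to compound 4, at least 3.2-fold (0.51 log units) apart, beyond the scatter of two such steps Compound 3 stands at a limit rather than a number, so the true size of the earlier step stays unknown, and two cores cannot show how the change would behave on a third: the limit of > 25000 nM in this assay, at which 1 of the 4 values shown sits.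

The compounds shown compare only these two methylphenyl groups, so they leave open how a plain phenyl or a 3-ethylphenyl on the nitrogen would read on either core. They also leave open which part of the core sets the size of the step, and a core carrying a carboxylic acid or an amine could help to test that.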